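Ring methyl on compound 3: expected loss of potency

The source may report more compounds than this note shows. Statements on the series, on what has been measured and on what is new or still open speak of the compounds shown alone.

Going by the values given here, compound 3 (`COC(=O)N(C)C(C)C#CCn1ccnc1`) gives 8 mg/kg in a functional assay on the whole organism for agonist activity, with Mus musculus as the target (a lower number here means that less compound is needed, a higher number that more compound is needed for the effect), the only number among the three compounds tested so far. Compound 4 (`COC(=O)N(C)C(C)C#CCn1cncc1C`) differs from compound 3 in one place: methyl in place of hydrogen on an aromatic carbon. Among the compounds with values here, no two tested compounds differ in a single place, and the effect of this methyl has not been measured directly.

The expectation rests on the other two tested compounds, which both carry a methyl on the ring. Compound 1 (`CC(=O)N(C)C(C)C#CCn1cncc1C`) gives > 100 mg/kg, which is a limit of the assay and not a number. Compound 2 (`COC(=O)N(C)CC#CCn1cncc1C`) gives > 100 mg/kg, likewise a limit of the assay. Within the data shown here, the main guide is therefore (the limit of > 100 mg/kg in this assay, at which 2 of the 3 values shown sit), and it is a weak one, since a limit gives no size for any step.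

A higher dose is expected for the methyl compound, with a change beyond the usual scatter. The expected step is a 5.0-fold higher number from compound 3 to compound 4 (0.70 log units; beyond the scatter). For compound 4 the estimated dose is 40 mg/kg, with an expected range from 10 mg/kg to 100 mg/kg. A result reported only as a limit remains quite possible.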

Compound 4, dose for half-maximal effect: > 100 mg/kg
Compound 4: only a limit was reported; the forecaster's own chance of this, stated with the estimate: 45%; at least 2.5-fold (0.39 log units) between middle value and limit.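

In this assay, the methyl in place of hydrogen on an aromatic carbon, next to the ring nitrogen and next to the ring atom that bears a large group, now has a direct reading with the rest of the compound unchanged: an at least 12-fold higher number from compound 3 to compound 4 (1.09 log units; beyond the scatter). Going by these compounds alone, this single added methyl is enough to take the one compound with a numeric dose to the limit of the assay, a link that the earlier compounds could not show, as none of them formed a pair with compound 3 differing only here. The result for compound 4 is a limit and not a number, so the step sets a minimum size only, and the steps to compound 4 from compound 1 and compound 2 cannot be read, as both ends of each are limits: the limit of > 100 mg/kg in this assay, at which 3 of the 4 values shown sit.

From the compounds shown here alone, how far compound 4 lies past the limit stays open, as does whether hydrogen in place of the ring methyl would give a numeric dose in compound 1 or compound 2. Also open, going by these compounds, is how an ethyl, a chlorine or a hydroxymethyl would read at this same ring carbon, so the present reading applies to methyl alone.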